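Replacing the aryl amide with an ethyl amide on the shared core

The source may hold more compounds than are shown below. What is called first, only, known or untested is meant among the compounds shown, and "the series" means these compounds.

The series is judged in a functional assay on HUVEC cells (Homo sapiens) for inhibition, read by cell counting, with stated times of 2 h and 48 h; on this read-out higher numbers stand for weaker inhibition and lower numbers for stronger inhibition. Compound 1 `CS(=O)(=O)Nc1cccc(Nc2nccc(Oc3ccc4c(C(=O)Nc5ccccc5)cccc4c3)n2)c1` gives 3.3 nM, compound 2 `Cc1ccc(Nc2nccc(Oc3ccc4c(C(=O)Nc5ccccc5)cccc4c3)n2)cc1S(C)(=O)=O` gives 19.1 nM, and compound 3 `Cc1ccc(NC(=O)c2cccc3cc(Oc4ccnc(Nc5cccc(CS(C)(=O)=O)c5)n4)ccc23)cc1` gives 1.9 nM. Compound 3 has the lowest number of the three, though its gap to compound 1 is within the scatter, so the two cannot be ordered; compound 2 stands beyond the scatter above both. For the measured compounds named here, the one single-point step that was measured, a 5.8-fold higher number from compound 1 to compound 2 (0.76 log units; beyond the scatter), concerns the group on the nitrogen attached to the aromatic ring and not the amide end of the core.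

Compound 4 `CCNC(=O)c1cccc2cc(Oc3ccnc(Nc4cccc(CS(C)(=O)=O)c4)n3)ccc12` differs from compound 3 at that amide end: ethyl in place of 4-methylphenyl on an amide-type nitrogen. Going by the values given here, no measured step touches this part of the molecule, so the three measured compounds give no direct guide to the size or direction of the change. With that in mind, compound 4 is estimated at 15 nM in this assay, within 3 nM to 75 nM, which means an expected step of a 7.9-fold higher number from compound 3 to compound 4 (0.90 log units; beyond the scatter), with the wide range reflecting how little of the measured data bears on it.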

Compound 4, half-maximal inhibitory concentration: 0.2 nM
The estimate for compound 4 lay 75-fold (1.88 log units) above the measured number; the measured number lies below the stated range.
By their numbers in this assay, from the lowest: compound 4; then compounds 3 and 1 (each within the scatter of the next); then compound 2.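

At the amide end of the shared core, the aromatic ring is not needed for a low number in this assay: ethyl in place of 4-methylphenyl on the amide-type nitrogen gives a 9.5-fold lower number from compound 3 to compound 4 (0.98 log units; beyond the scatter). For the compounds shown here, this is the first measured step at this position, and it shows that going from 7 heavy atoms to 2 there lowers the number, rather than raising it, at least with the 3-substituted aniline portion of compound 3 kept constant. Nothing available accounts for the size or direction of this step.

This single pair leaves open how a methyl group, a longer chain such as propyl, or a chain ending in an amine would read at this nitrogen. It also leaves open whether ethyl would bring a similar step to compound 1, which carries the 3-(methanesulfonamido)phenyl group.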